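The source may report more compounds than this note shows. Statements on the series, on what has been measured and on what is new or still open speak of the compounds shown alone.

Measured in a functional assay on microsomes from liver (Rattus norvegicus, strain Wistar) for inhibition, read by spectrophotometry, with a stated time of 60 min (on this read-out lower numbers stand for stronger inhibition and higher numbers for weaker inhibition), so far
- compound 1 `COc1ccc(C(=O)ON=C2CC(c3ccc(O)c(OC)c3)N(C)C(c3ccc(O)c(OC)c3)C2)c(OC)c1` gives 52000 nM
- compound 2 `COc1cc(C2CC(=NOC(=O)c3ccccc3O)CC(c3ccc(O)c(OC)c3)N2C)ccc1O` gives 24100 nM
- compound 3 `COc1cc(C2CC(=NOC(=O)c3ccc(O)cc3)CC(c3ccc(O)c(OC)c3)N2C)ccc1O` gives 22500 nM

On these numbers compound 2 stands level with its nearest neighbour (a 1.1-fold lower number from compound 2 to compound 3 (0.03 log units; within the scatter)) and under the highest number (a 2.2-fold lower number from compound 1 to compound 2 (0.33 log units; beyond the scatter)). Compound 4 `COc1cc(C2CC(=NO)CC(c3ccc(O)c(OC)c3)N2C)ccc1O` has not yet been measured. It differs from compound 2 in one place, with hydrogen in place of (2-hydroxyphenyl)carbonyl on an oxygen.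

The measured steps bear on this change only in part. Each of them swaps one phenyl group on a carbonyl carbon for another, and the carbonyl itself stays. Among the measured compounds shown here, no measured compound lacks that carbonyl, so the data hold no direct test of removing it. Going by compound 3 and the modest step (a 2.3-fold lower number from compound 1 to compound 3 (0.36 log units; beyond the scatter)), a small change is expected in this assay with no direction that the data can fix and with wide uncertainty. The estimated step is a 1.2-fold higher number from compound 2 to compound 4 (0.10 log units; within the scatter) and would lie within the scatter. For compound 4 the expected value is 30000 nM within an estimated range (12000 nM to 75000 nM).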

Compound 4, half-maximal inhibitory concentration: 167000 nM
Compound 4: the middle estimate sits 5.6-fold (0.75 log units) below what was measured; measured number outside the range, above it.
By their numbers in this assay, from the lowest: compounds 3 and 2 (each within the scatter of the next); then compound 1; then compound 4.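

In this assay, all three ester groups on this oxygen can now be compared with plain hydrogen, and each removal goes the same way, towards weaker inhibition: hydrogen in place of (2-hydroxyphenyl)carbonyl gives a 6.9-fold higher number from compound 2 to compound 4 (0.84 log units; beyond the scatter), hydrogen in place of (4-hydroxyphenyl)carbonyl gives a 7.4-fold higher number from compound 3 to compound 4 (0.87 log units; beyond the scatter), and hydrogen in place of (2,4-dimethoxyphenyl)carbonyl gives a 3.2-fold higher number from compound 1 to compound 4 (0.51 log units; beyond the scatter). The earlier compounds shown here showed only that the choice of phenyl group on the carbonyl made a modest difference or none, whereas these steps show that having such a group on this oxygen at all matters, with the free hydroxy compound 4 the weakest of the four. No measurement offered here accounts for this loss in inhibition.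

The compounds shown leave open whether the carbonyl or the phenyl ring carries the difference, since all three esters hold both together. An acetyl group, a methyl ether or a benzyl ether on the same oxygen would separate the two.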